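The source may hold more compounds than are shown below. What is called first, only, known or untested is meant among the compounds shown, and "the series" means these compounds.

Three compounds have been measured in a functional assay on MCF7 cells (Homo sapiens) for cytotoxicity, read by MTT assay, with a stated time of 72 h; on this read-out higher numbers stand for weaker inhibition and lower numbers for stronger inhibition:
Compound 1, `CCNC(=O)N1CCN(C(=S)SCc2cn(Cc3ccccc3F)nn2)CC1`, gives 5760 nM.
Compound 2, `CC(C)NC(=O)N1CCN(C(=S)SCc2cn(Cc3ccccc3F)nn2)CC1`, gives 1860 nM.
Compound 3, `O=C(NCc1ccccc1)N1CCN(C(=S)SCc2cn(Cc3ccccc3F)nn2)CC1`, gives 38100 nM.

Compound 2 stands at the lowest number of the three in this assay. The step of a 3.1-fold lower number from compound 1 to compound 2 (0.49 log units; beyond the scatter) separates it from compound 1, and the step of a 20-fold higher number from compound 2 to compound 3 (1.31 log units; beyond the scatter) separates it from compound 3; the step of a 6.6-fold higher number from compound 1 to compound 3 (0.82 log units; beyond the scatter) completes the set. All three measured steps change the group on the amide-type nitrogen at one end of the shared core, while the 2-fluorobenzyl group at the other end stays the same throughout.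

Compound 4, `CC(C)NC(=O)N1CCN(C(=S)SCc2cn(Cc3ccc(F)cc3)nn2)CC1`, keeps the isopropyl group of compound 2 and changes only that other end: 4-fluorophenyl in place of 2-fluorophenyl on a saturated chain carbon bound to an aromatic nitrogen. Within the data shown here, no measured step touches this part of the structure, so none of the three steps bears directly on the change; they show only that the numbers in this set can move over a wide range when the amide-type nitrogen end is altered. Among the measured compounds shown here, with no comparable step in hand, the step from compound 2 to compound 4 in this assay is expected to stay within the scatter, in no particular direction, and a 1.1-fold higher number from compound 2 to compound 4 (0.03 log units; within the scatter) expresses that expectation. Compound 4 is therefore estimated at 2000 nM, with an expected range from 700 nM to 6000 nM.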

Compound 4, half-maximal inhibitory concentration: 1660 nM
For compound 4 the middle estimate is 1.2-fold (0.08 log units) above the measured one; measured number inside the range.
By their numbers in this assay, from the lowest: compounds 4 and 2 (each within the scatter of the next); then compound 1; then compound 3.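

Replacing 2-fluorophenyl with 4-fluorophenyl on a saturated chain carbon bound to an aromatic nitrogen is the first change shown at this end of the molecule, and in this assay it gives a 1.1-fold lower number from compound 2 to compound 4 (0.05 log units; within the scatter) on the isopropyl series. For this pair, then, the place of the fluorine on the phenyl ring makes no difference that the assay can detect, whereas a change at the amide-type nitrogen can give a step as large as a 20-fold higher number from compound 2 to compound 3 (1.31 log units; beyond the scatter) in the same assay. No evidence is available here on why compound 2 and compound 4 read alike.

On these data alone, this single pair has the isopropyl group held fixed, so it remains open whether the same fluorine change would also read alike with the ethyl group of compound 1 or the benzyl group of compound 3. The compounds shown also leave open what happens if the fluorine on this ring gives way to a chlorine, a methoxy group or a nitrile, or if the ring is removed altogether.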